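This account rests on a few compounds, and the source may have more. Where it says the series, first, only, none or still open, it means among the compounds named here.

Measured compounds:
Compound 1, `COCc1cc(=O)oc2cc(O)ccc12`: 5000 nM
Compound 2, `CN(Cc1cc(=O)oc2cc(O)ccc12)c1ccccc1`: 6000 nM

In an assay on HeLa cells for inhibition of 17-beta-hydroxysteroid dehydrogenase type 3 (Homo sapiens) (a lower number here means a stronger inhibitor, a higher number a weaker inhibitor), compound 1 gives 5000 nM and compound 2 gives 6000 nM; the two values lie within the scatter of each other, so neither stands apart. Compound 3, `O=c1cc(CSc2nncs2)c2ccc(O)cc2o1`, has not yet been measured in this assay. Its difference from compound 1 is (1,3,4-thiadiazol-2-yl)sulfanyl in place of methoxy on a saturated chain carbon bound to an aromatic carbon. Among the compounds with values here, no step between measured compounds covers such a change, so the expectation rests only on the two values shown. A small step, not clearly beyond the scatter and with no firm direction, is expected. Compound 3 is estimated at 3500 nM, with a range from 900 nM to 14000 nM, meaning an expected step of a 1.4-fold lower number from compound 1 to compound 3 (0.15 log units; within the scatter).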

Compound 3, half-maximal inhibitory concentration: 200 nM
The estimate for compound 3 lay 18-fold (1.24 log units) above the measured number, and the stated range ends above it.
By their numbers in this assay, from the lowest: compound 3; then compounds 1 and 2 (each within the scatter of the next).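

In this assay, putting (1,3,4-thiadiazol-2-yl)sulfanyl in place of methoxy on a saturated chain carbon bound to an aromatic carbon gives a 25-fold lower number from compound 1 to compound 3 (1.40 log units; beyond the scatter), a step far beyond the scatter. Within the data shown here, compounds 1 and 2 alone gave no sign that this position could move the number so far. No measurement here explains the drop. Going by these compounds, compound 3 brings in the sulfur link and the ring together, so which part matters stays open. On these data alone, how a methylsulfanyl or a phenylsulfanyl group would compare in this place is also open.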